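Adding a methoxy group to the benzyl of compound 2

This account rests on a few compounds, and the source may have more. Where it says the series, first, only, none or still open, it means among the compounds named here.

Compound 1 `NC(=O)CN1CCN(c2nc(-c3ccccn3)nc3c2CN(Cc2ccccc2)CC3)CC1`: in an assay on A549 cells with Cystic fibrosis transmembrane conductance regulator variant F508del (Homo sapiens) as the target, read by fluorescence, with a stated time of 25 min (a lower number here means a smaller maximal response, a higher number a larger maximal response), compound 1 gave "not active" (no number reported), with no number reported.
Compound 2 `CN(C)CCN1CCN(c2nc(-c3ccccn3)nc3c2CN(Cc2ccccc2)CC3)CC1`: in this assay compound 2 gave 57%.

Within the data shown here, compound 2 therefore stands as the only compound with a number here; compound 1 offers nothing to compare it against. Compound 3 `COc1ccc(CN2CCc3nc(-c4ccccn4)nc(N4CCN(CCN(C)C)CC4)c3C2)cc1` keeps the whole of compound 2 and changes one spot: methoxy in place of hydrogen on an aromatic carbon. Among the measured compounds shown here, no step between two measured compounds is available, so the size of this change cannot be read from earlier data. With a single number to rest on, the change is expected to stay near the scatter, with no direction favoured. The largest response of compound 3 in this assay is expected at 55%, between 35% and 75%. This means an expected step of a number 2 percentage points lower from compound 2 to compound 3 (within the scatter).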

Compound 3, largest response reached (Emax), in percent of the reference or control that the assay uses: "not active" (no number reported)
The entry for compound 3 holds no number; there is nothing to compare the estimate with.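

Among these compounds, compound 3 carries no number in this assay and so gives no step from compound 2 that can be read. On these data alone, how far the 4-methoxybenzyl group shifts the largest response stays open. Nothing shown here bears on this result.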